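This account rests on a few compounds, and the source may have more. Where it says the series, first, only, none or still open, it means among the compounds named here.

Compound 1 `C[n+]1cccc(OP(=O)([O-])OC[C@H]2O[C@@H](n3cc(F)c(=O)[nH]c3=O)C[C@@H]2OC(=O)c2ccccc2)c1`: 590 nM
Compound 2 `O=C(O[C@H]1C[C@H](n2cc(F)c(=O)[nH]c2=O)O[C@@H]1COP(=O)([O-])Oc1ccc[n+](Cc2ccccc2)c1)c1ccccc1`: 660 nM
Compound 3 `CCOC(=O)C[n+]1cccc(OP(=O)([O-])OC[C@H]2O[C@@H](n3cc(F)c(=O)[nH]c3=O)C[C@@H]2OC(=O)c2ccccc2)c1`: 580 nM

In a functional assay on U-87MG ATCC cells for cytotoxicity against U-87 MG (Homo sapiens), read by MTT assay, with a stated time of 48 h (a lower number here means a stronger inhibitor, a higher number a weaker inhibitor), compound 3 gives 580 nM, a value that cannot be told apart from those of the other two compounds. Compound 4 `C[N+]1(C)CCC(OP(=O)([O-])OC[C@H]2O[C@@H](n3cc(F)c(=O)[nH]c3=O)C[C@@H]2OC(=O)c2ccccc2)CC1` differs from compound 3 by one exchange: a group of 8 heavy atoms (7 carbon, 1 nitrogen; one six-membered non-aromatic ring with 1 hetero atom) in place of a group of 12 heavy atoms (9 carbon, 1 nitrogen, 2 oxygen; one six-membered aromatic ring with 1 hetero atom), on an oxygen. The measured steps are all small: a 1.1-fold higher number from compound 1 to compound 2 (0.05 log units; within the scatter), a 1.0-fold lower number from compound 1 to compound 3 (0.01 log units; within the scatter) and a 1.1-fold lower number from compound 2 to compound 3 (0.06 log units; within the scatter). Each of them changed only a group on a saturated chain carbon bound to an aromatic nitrogen, so none tests the replacement of the aromatic ring itself. With that gap in mind, no change beyond the scatter is expected, though with limited confidence. The expected step is a 1.2-fold higher number from compound 3 to compound 4 (0.08 log units; within the scatter). The estimate for compound 4 is 700 nM, with an expected range from 250 nM to 2000 nM.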

Compound 4, half-maximal inhibitory concentration: 1280 nM
Estimate against measurement, compound 4: 1.8-fold (0.26 log units) below; the range from low to high includes it.
By their numbers in this assay, from the lowest: compounds 3, 1, 2 and 4 (each within the scatter of the next, the first and the last beyond it).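

Changing the group on the saturated chain carbon bound to an aromatic nitrogen left the numbers in this assay indistinguishable, but exchanging the whole group on the oxygen bound to phosphorus does move them (a 2.2-fold higher number from compound 3 to compound 4 (0.34 log units; beyond the scatter); a 2.2-fold higher number from compound 1 to compound 4 (0.34 log units; beyond the scatter)). Both steps are modest and point towards a weaker inhibitor, so the aromatic ring with 1 hetero atom cannot be swapped for the non-aromatic ring without some loss here. Nothing available explains this loss.

As far as these compounds go, whether the ring nitrogen itself matters stays open. A cyclohexyl group on that oxygen, which has no nitrogen, would address this.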